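Chain-end aryl groups: from compound 2 to compound 3

The source may hold more compounds than are shown below. What is called first, only, known or untested is meant among the compounds shown, and "the series" means these compounds.

Values in a functional assay on A549 cells (Homo sapiens) for cytotoxicity; on this read-out lower numbers stand for stronger inhibition and higher numbers for weaker inhibition:
- Compound 1 `C=C/C=C\[C@H](C)[C@H](OC(N)=O)[C@@H](C)[C@H](O)[C@@H](C)C/C(C)=C\[C@H](C)[C@@H](O)[C@@H](C)/C=C\CCc1cccc(F)c1`: 650 nM
- Compound 2 `C=C/C=C\[C@H](C)[C@H](OC(N)=O)[C@@H](C)[C@H](O)[C@@H](C)C/C(C)=C\[C@H](C)[C@@H](O)[C@@H](C)/C=C\CCc1ccsc1`: 4000 nM
- Compound 3 `C=C/C=C\[C@H](C)[C@H](OC(N)=O)[C@@H](C)[C@H](O)[C@@H](C)C/C(C)=C\[C@H](C)[C@@H](O)[C@@H](C)/C=C\CCc1cc(O)cc(O)c1`: not yet measured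

Compound 2 holds the higher of the two numbers, 4000 nM, while compound 1 gives 650 nM. The next change is 3,5-dihydroxyphenyl in place of thiophen-3-yl on a saturated chain carbon, two bonds along the chain from a double-bonded chain carbon. Going by the values given here, one measured step bears on it, at the same place: a 6.2-fold higher number from compound 1 to compound 2 (0.79 log units; beyond the scatter), modest and beyond the scatter. Compound 3 returns to a phenyl ring, as in compound 1, but no hydroxylated group has been measured. A smaller step towards a lower number in this assay is therefore expected, possibly none beyond the scatter. The expected step is a 1.6-fold lower number from compound 2 to compound 3 (0.20 log units; within the scatter). For compound 3 the estimated value is 2500 nM, with an expected range of 600 nM to 10000 nM.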

Compound 3, half-maximal inhibitory concentration: 310 nM
The estimate for compound 3 lay 8.1-fold (0.91 log units) above the measured number; measured number outside the range, below it.
By their numbers in this assay, from the lowest: compound 3; then compound 1; then compound 2.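

In this assay, the chain-end position accepts a ring bearing hydroxyl groups: 3,5-dihydroxyphenyl in place of thiophen-3-yl gives a 13-fold lower number from compound 2 to compound 3 (1.11 log units; beyond the scatter), a large step and more than the step seen earlier between the two other aryl groups. The same group in place of 3-fluorophenyl gives a 2.1-fold lower number from compound 1 to compound 3 (0.32 log units; beyond the scatter), a modest step beyond the scatter, so compound 3 holds the lowest number of the three and the 3-fluorophenyl ring does not mark the low end at this position. Nothing available on these compounds accounts for the change in the number.

Open, from the compounds shown here alone, is whether one hydroxyl, as in 3-hydroxyphenyl, would keep the number at this level, or whether methyl ethers, as in 3,5-dimethoxyphenyl, would. Also open, going by these compounds, is how an amine on the ring would read here.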